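Nitro for Hydrogen on Two Cores, One Step Unread

The source may hold more compounds than are shown below. What is called first, only, known or untested is meant among the compounds shown, and "the series" means these compounds.

Compound 1, `CNC(=O)c1cc(Oc2ccc(NS(=O)(=O)c3ccccc3)cc2)ccn1`: > 40000 nM
Compound 2, `CNC(=O)c1cc(Oc2ccc(NS(=O)(=O)c3ccccc3[N+](=O)[O-])cc2)ccn1`: > 40000 nM
Compound 3, `O=C(Nc1ccc(Oc2ccnc3ccccc23)cc1)c1cc(C(F)(F)F)cc(C(F)(F)F)c1`: 16000 nM

Three compounds were measured in a functional assay on PLC-PRF-5 cells (Homo sapiens) for inhibition; a lower number here means a stronger inhibitor, a higher number a weaker inhibitor. Compound 1 reaches only the limit of the assay, > 40000 nM, which is not a number. Compound 2 likewise reaches only the limit, > 40000 nM. Among the compounds with values here, compound 3 is the one compound with a number, 16000 nM.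

Compound 2 differs from compound 1 by nitro in place of hydrogen on an aromatic carbon. The step that the two limits leave unreadable from compound 1 to compound 2 cannot be read, since the limit of > 40000 nM in this assay, at which 2 of the 3 values shown sit, covers both ends of it.

Compound 4, `O=C(Nc1ccc(Oc2ccnc3c([N+](=O)[O-])cccc23)cc1)c1cc(C(F)(F)F)cc(C(F)(F)F)c1`, is not yet measured. It differs from compound 3 by nitro in place of hydrogen on an aromatic carbon. This is the same kind of change as that from compound 1 to compound 2, but not the same: there the nitro group sits ortho to a large group, here it sits on a ring that is part of a fused or bridged system of two rings, ortho to a fused ring and meta to a fused ring. The difference between the two cores is not broken down here.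

Within the data shown here, with the only earlier step of this kind unreadable, the expected step for compound 4 is no change at the digits printed from compound 3 to compound 4 (within the scatter), resting simply on compound 3 at 16000 nM. Compound 4 is therefore estimated at 16000 nM in this assay, between 5000 nM and 40000 nM.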

Compound 4, half-maximal inhibitory concentration: > 40000 nM
Compound 4: no number, only a limit; the forecaster's own chance of this, stated with the estimate: 30%; at least 2.5-fold (0.39 log units) between middle value and limit.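

On these data alone, on the core of compound 3, nitro in place of hydrogen on an aromatic carbon of the fused system gives in this assay an at least 2.5-fold higher number from compound 3 to compound 4 (0.39 log units; beyond the scatter) and so goes with a weaker inhibitor on this core, although the full size of the step stays unknown. Compound 4 stands at > 40000 nM as a limit of the assay and not a number. This single step shows that the change did not improve inhibition on this core, but it does not show that the change acts alike on both cores, because the step from compound 1 to compound 2 cannot be read and the comparison has only one readable side: the limit of > 40000 nM in this assay, at which 3 of the 4 values shown sit.

The compounds shown leave open whether any replacement on that aromatic carbon could give a stronger inhibitor than compound 3 at 16000 nM in this series, for instance an amine or a carboxylic acid in place of the nitro group. They also leave open whether nitro would give the same result on another carbon of that ring, and what the change does on the core of compound 1 when the parent compound has a value that is a number.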